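The source may report more compounds than this note shows. Statements on the series, on what has been measured and on what is new or still open speak of the compounds shown alone.

Values in a functional assay on J774 cells (Mus musculus) for cytotoxicity; on this read-out higher numbers stand for weaker inhibition and lower numbers for stronger inhibition:

- compound 1 `CCCN(CCC)c1c([N+](=O)[O-])cc(S(=O)(=O)Nc2ccc(OC)cc2)cc1[N+](=O)[O-]` gives 15000 nM
- compound 2 `CCCN(CCC)c1c([N+](=O)[O-])cc(S(=O)(=O)Nc2ccc(Cl)cc2)cc1[N+](=O)[O-]` gives 10000 nM
- compound 3 `CCCN(CCC)c1c([N+](=O)[O-])cc(S(=O)(=O)Nc2cccc(OC)c2)cc1[N+](=O)[O-]` gives 25000 nM

Compound 3 stands at 25000 nM in this small set. Its closer neighbour is given by a 1.7-fold higher number from compound 1 to compound 3 (0.22 log units; within the scatter) and its further one by a 2.5-fold higher number from compound 2 to compound 3 (0.40 log units; beyond the scatter) on the same read-out.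

The next member, compound 4 `CCCN(CCC)c1c([N+](=O)[O-])cc(S(=O)(=O)Nc2cccc(C)c2)cc1[N+](=O)[O-]`, carries methyl in place of methoxy on an aromatic carbon, meta to a large group (methyl in place of methoxy on an aromatic carbon). Going by the values given here, no measured step makes this exact exchange. The closest evidence is the replacement of methoxy by chloro (a 1.5-fold lower number from compound 1 to compound 2 (0.18 log units; within the scatter)) and the shift of the methoxy group (a 1.7-fold higher number from compound 1 to compound 3 (0.22 log units; within the scatter)), and both stay within the scatter. Only a 2.5-fold higher number from compound 2 to compound 3 (0.40 log units; beyond the scatter) goes beyond it, modestly, and that step changes both the group and its place.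

The estimated step is a 1.4-fold lower number from compound 3 to compound 4 (0.14 log units; within the scatter), so no shift beyond the scatter is expected in this assay. Compound 4 is expected at 18000 nM, with an estimated range of 8000 nM to 40000 nM.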

Compound 4, half-maximal inhibitory concentration: 16000 nM
Compound 4: the middle estimate sits 1.1-fold (0.05 log units) above what was measured, within the range that was stated.
By their numbers in this assay, from the lowest: compounds 2, 1, 4 and 3 (each within the scatter of the next, the first and the last beyond it).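

In this assay, methyl in place of methoxy on an aromatic carbon, meta to a large group, now has a direct reading at this position: a 1.6-fold lower number from compound 3 to compound 4 (0.19 log units; within the scatter) stays within the scatter. Going by these compounds alone, the 3-methylphenyl group also stays within the scatter of both 4-chlorophenyl, with a 1.6-fold higher number from compound 2 to compound 4 (0.20 log units; within the scatter), and 4-methoxyphenyl, with a 1.1-fold higher number from compound 1 to compound 4 (0.03 log units; within the scatter), so the only gap beyond the scatter remains the one between compound 2 and compound 3, where group and place change together. Nothing available bears on the cause of these small steps.

From the compounds shown here alone, whether an amine, a carboxylic acid or a longer chain at this place would move the number beyond the scatter stays open. Also open, going by these compounds, is whether 3-chlorophenyl, which would separate the chloro group from its place, falls closer to compound 2 or to compound 3.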